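Cytotoxicity of Compound 1 and an Expected Compound 4

A few compounds are considered here, and "the series" means these few. Any claim that something is new, unique, unknown or untested is made for them only; others in the source may bear on it.

Compound 1 `COc1c(OCc2cnoc2C)cc(O)c2c(=O)cc(-c3ccccc3)oc12` was examined in a functional assay on A549 cells (Homo sapiens) for cytotoxicity, read by MTT assay, with a stated time of 48 h; on this read-out higher numbers stand for weaker inhibition and lower numbers for stronger inhibition. In this assay compound 1 gave only > 100000 nM, which is a limit of the assay rather than a number. Compound 3 `CN1CCN(CCCCOc2c(O)cc(O)c3c(=O)cc(-c4ccccc4)oc23)CC1` also gave only a limit in this assay, > 100000 nM. Compound 2 `COc1c(O)cc(O)c2c(=O)cc(-c3ccc(Cl)cc3)oc12` has no result in this assay, recorded as "not determined" (no result reported). Compound 1 thus stands at the limit of > 100000 nM in this assay, at which 2 of the 3 values shown sit, so no measured number places it among the others. Compound 4 `COc1c(OCCCCN2CCN(C)CC2)cc(O)c2c(=O)cc(-c3ccccc3)oc12` differs from compound 1 by 3-(4-methylpiperazin-1-yl)propyl in place of 5-methyl-1,2-oxazol-4-yl on a saturated chain carbon bound to an oxygen on an aromatic ring. Among the compounds with values here, no step between two measured compounds is available to set the size of this change. The expected step is a number no higher from compound 1 to compound 4 (the limit leaves the size open), none beyond the usual scatter. Compound 4 is therefore estimated at 100000 nM, with a range from 30000 nM to 300000 nM, most likely again reported only as a limit.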

Compound 4, half-maximal inhibitory concentration: 1500 nM
Compound 4: middle estimate off by 67-fold (1.82 log units), on the high side; measured number below the stated range.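

In this assay, 3-(4-methylpiperazin-1-yl)propyl in place of 5-methyl-1,2-oxazol-4-yl gives an at least 66-fold lower number from compound 1 to compound 4 (1.82 log units; beyond the scatter). Within the data shown here, this shows that the group on this saturated chain carbon bound to an oxygen on an aromatic ring can decide whether the core gives a measurable number here, which the earlier compounds did not show. Compound 1 has only a limit of the assay, so the full size of the step stays unknown: the limit of > 100000 nM in this assay, at which 2 of the 4 values shown sit.

The compounds shown do not separate the contribution of the chain from that of the methylpiperazine ring. A morpholine ring or a simple dimethylamine on the same chain would bear on that question.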